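This account rests on a few compounds, and the source may have more. Where it says the series, first, only, none or still open, it means among the compounds named here.

Measured in an ADME assay (liver) for metabolic stability, with Liver microsome (Rattus norvegicus) as the target, read by LC-MS, using microsomes, with a stated time of 30 min, tested at 4 uM; a lower number here means that less of the compound is left, a higher number that more of the compound is left:
- compound 1 `CCN1CCN(c2nc(C)nc3c2nc(-c2ccccc2Cl)n3C)CC1`: 30%
- compound 2 `CCN1CCN(c2nc(C)nc3c2nc(-c2ccccc2Cl)n3CCOC)CC1`: 53%
- compound 3 `Cc1nc(N2CCN(C)CC2)c2nc(-c3cccc(Cl)c3)n(C3CCOCC3)c2n1`: 45%

With 45%, compound 3 cannot be told apart from compound 2, as the two lie within the usual scatter of each other. Compound 3 does stand clearly higher than compound 1, with the gap beyond the scatter.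

The next compound is compound 4 `Cc1nc(N2CCN(C)CC2)c2nc(-c3ccccc3F)n(C3CCOCC3)c2n1`, which has 2-fluorophenyl in place of 3-chlorophenyl on an aromatic carbon. Among the measured compounds shown here, only one step between measured compounds is available, a number 23 percentage points higher from compound 1 to compound 2 (beyond the scatter). That modest step puts methoxymethyl in place of hydrogen on a saturated chain carbon, elsewhere in the molecule. It therefore shows how far this assay can move, but no measurement tests an exchange of the aromatic group itself. With no direct evidence for a shift in either direction, no change beyond the scatter is expected.

The estimated result is a number 2 percentage points higher from compound 3 to compound 4 (within the scatter).

For compound 4, the expected value is 47%, with an estimated range from 31% to 63%.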

Compound 4, percent of the compound remaining: 30%
Compound 4: middle estimate off by 17 percentage points, on the high side; the measured number lies below the stated range.
By their numbers in this assay, from the lowest: compounds 1 and 4 (each within the scatter of the next); then compounds 3 and 2 (each within the scatter of the next).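

The aromatic group on this carbon of the five-membered ring, which bears the oxan-4-yl group on the neighbouring ring atom, clearly matters in this assay: a number 15 percentage points lower from compound 3 to compound 4 (beyond the scatter). Among the compounds shown here, this is the first measured exchange at this position, and it shows that swapping one halogen-bearing phenyl group for another of the same heavy-atom count can shift the read-out beyond the scatter. No measurement shown explains why the number falls.

The exchange changes both the halogen and its place on the phenyl ring, so the compounds shown cannot say which of the two accounts for the step. A 3-fluorophenyl or plain phenyl group at this position, with the rest of compound 3 kept, would be needed to separate them.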